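Weak amides: a fluorophenyl replacement on the shared core

The source may report more compounds than this note shows. Statements on the series, on what has been measured and on what is new or still open speak of the compounds shown alone.

Compound 2 `C=CC(=O)Nc1cccc(NC(=O)CSc2nc(Nc3ccccc3)c3ccccc3n2)c1` has the lowest of the two numbers in a functional assay on NCI-H1975 cells (Homo sapiens) for inhibition, read by MTT assay, with a stated time of 72 h (a higher number here means a weaker inhibitor, a lower number a stronger inhibitor), where compound 2 gives 8120 nM; its nearest neighbour is compound 1 `O=C(CSc1nc(Nc2ccccc2)c2ccccc2n1)Nc1cccc(Cl)c1`, which in this assay gives 8460 nM, and a 1.0-fold lower number from compound 1 to compound 2 (0.02 log units; within the scatter). Compound 3 `O=C(CSc1nc(Nc2ccccc2)c2ccccc2n1)Nc1ccc(F)cc1` differs from compound 2 in one place: 4-fluorophenyl in place of 3-((vinylcarbonyl)amino)phenyl on an amide-type nitrogen. Among the measured compounds shown here, the only step that bears on this exchange, from compound 1 to compound 2, stayed within the scatter, so no shift beyond the scatter is expected in this assay. Compound 3 is therefore estimated at 9000 nM, with a range of 3000 nM to 27000 nM, which means an expected step of a 1.1-fold higher number from compound 2 to compound 3 (0.04 log units; within the scatter).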

Compound 3, half-maximal inhibitory concentration: 16500 nM
Compound 3: the middle estimate sits 1.8-fold (0.26 log units) below what was measured; low and high end bracket the measured number.
By their numbers in this assay, from the lowest: compounds 2, 1 and 3 (each within the scatter of the next, the first and the last beyond it).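

In this assay, a 2.0-fold higher number from compound 2 to compound 3 (0.31 log units; beyond the scatter) shows that exchanging 3-((vinylcarbonyl)amino)phenyl for 4-fluorophenyl on the amide-type nitrogen can pass the scatter, though only modestly, which the earlier step did not show. Exchanging 3-chlorophenyl for 4-fluorophenyl at the same place gives a 2.0-fold higher number from compound 1 to compound 3 (0.29 log units; within the scatter) and so does not separate the two halogen-bearing phenyl groups. Nothing available explains either step. On these data alone, how an amine or a carboxylic acid on this phenyl ring would read in this assay remains open.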